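Swapping the pyrazolyl amine for benzamido

The source may hold more compounds than are shown below. What is called first, only, known or untested is meant among the compounds shown, and "the series" means these compounds.

Values in a physicochemical assay for lipophilicity, using the shake flask method, in phosphate buffer, measured as octanol-water partition, with a stated time of 30 min, at pH 7.4; a higher number here means a more lipophilic compound, a lower number a more polar compound:
compound 1 `CN(c1ccccc1)c1cnc(NCc2c(F)ccc3c2CCO3)n2cnnc12`: 3.6
compound 2 `CN(c1ccn(C)n1)c1cnc(NCc2c(F)ccc3c2CCO3)n2cnnc12`: 1.8

Of the two measured compounds, compound 2 has the lower number, 1.8. Compound 3 `O=C(Nc1cnc(NCc2c(F)ccc3c2CCO3)n2cnnc12)c1ccccc1` has benzamido in place of methyl(1-methyl-1H-pyrazol-3-yl)amino on an aromatic carbon. Among the measured compounds shown here, one measured step bears on this change: a number 1.80 log units lower from compound 1 to compound 2 (beyond the scatter), a large step that came with 1-methyl-1H-pyrazol-3-yl in place of phenyl on a nitrogen. Compound 3 also loses the five-membered aromatic ring and carries a six-membered aromatic ring of carbon only, as compound 1 does at 3.6. For the measured compounds named here, no measured compound shows what the benzamido group itself does. Most, but not all, of the gap is therefore expected to be recovered in this assay, as an estimated upward step of a number 1.20 log units higher from compound 2 to compound 3 (beyond the scatter). The expected value for compound 3 is 3, with an estimated range of 2.5 to 3.5.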

Compound 3, distribution coefficient: 3
Beside the measured number, compound 3's estimate shows no gap at the digits printed; the range from low to high includes it.
By their numbers in this assay, from the lowest: compound 2; then compound 3; then compound 1.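

In this assay, the position responds strongly when benzamido replaces methyl(1-methyl-1H-pyrazol-3-yl)amino on an aromatic carbon, with a number 1.20 log units higher from compound 2 to compound 3 (beyond the scatter). The ring alone does not set the number: methyl(phenyl)amino and benzamido both carry a six-membered aromatic ring of carbon only, yet the change between them gives a number 0.60 log units lower from compound 1 to compound 3 (beyond the scatter), so the link joining that ring to the shared core also matters here. No supporting data are available to explain either step.

Still open, on these data alone, is how the amide link behaves with the five-membered ring, as in 1-methyl-1H-pyrazole-3-carboxamido, which would show whether the two changes add up. Also open, as far as these compounds go, is what acetamido, which has no ring, would give at this position.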